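This account rests on a few compounds, and the source may have more. Where it says the series, first, only, none or still open, it means among the compounds named here.

Measured so far:
Compound 1 `CN1C(=O)C(CC2CC2)N(C)c2nc(Nc3ccc(S(N)(=O)=O)cc3)ncc21` gives 211 nM
Compound 2 `CN1C(=O)C(c2ccccc2Cl)N(C)c2nc(Nc3ccc(S(N)(=O)=O)cc3)ncc21` gives 129 nM

In an assay on Sf9 cells for inhibition of serine/threonine-protein kinase 4 (Homo sapiens), read by luminescence and ADP-Glo, with a stated time of 1 h, in the presence of a further agent that is not named here (a higher number here means a weaker inhibitor, a lower number a stronger inhibitor), compound 2 stands at the lower of these two numbers, yet the step of a 1.6-fold lower number from compound 1 to compound 2 (0.21 log units; within the scatter) is within the scatter. Compound 3 `Cc1ccc(F)cc1C1C(=O)N(C)c2cnc(Nc3ccc(S(N)(=O)=O)cc3)nc2N1C` differs from compound 2 by 5-fluoro-2-methylphenyl in place of 2-chlorophenyl on a saturated ring carbon. Among the compounds with values here, the only measured step at this position, a 1.6-fold lower number from compound 1 to compound 2 (0.21 log units; within the scatter), swapped one group for another without leaving the scatter, so no step beyond the scatter is expected for compound 3 in this assay. The expected step is a 1.0-fold higher number from compound 2 to compound 3 (0.00 log units; within the scatter). Compound 3 is therefore estimated at 130 nM, with a range from 50 nM to 350 nM.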

Compound 3, half-maximal inhibitory concentration: 168 nM
Compound 3: the middle estimate sits 1.3-fold (0.11 log units) below what was measured; the range from low to high includes it.
By their numbers in this assay, from the lowest: compounds 2, 3 and 1 (each within the scatter of the next).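

In this assay, a second substituted phenyl at this saturated ring carbon gives a 1.3-fold higher number from compound 2 to compound 3 (0.11 log units; within the scatter), and set against the cyclopropylmethyl group it gives a 1.3-fold lower number from compound 1 to compound 3 (0.10 log units; within the scatter). Within the data shown here, the position has now carried 2-chlorophenyl, 5-fluoro-2-methylphenyl and cyclopropylmethyl with no step leaving the scatter, so adding the fluorine and swapping chlorine for methyl on the phenyl ring shows no readable effect here. Still open, on these data alone, is whether a different kind of group on this carbon, such as an amine or a carboxylic acid, would produce a step beyond the scatter. Nothing at hand offers an explanation for these closely matched numbers.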